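Swapping Cyclohexyl for a Hydroxyl-Rich Chain

This account rests on a few compounds, and the source may have more. Where it says the series, first, only, none or still open, it means among the compounds named here.

In an assay on CHO cells for displacement of a labelled ligand from adenosine receptor A1 (Homo sapiens), read by scintillation counting, with a stated time of 60 min, tested at 10 uM (a lower number here means less inhibition, a higher number more inhibition at the concentration tested (going by the name of the read-out)), compound 3 `COc1cccc2cc(C(=O)NC3CCCCC3)c(=N)oc12` gives 40%, the highest of the two plain numbers shown, while compound 2 `CCC(CO)NC(=O)c1cc2cccc(OC)c2oc1=N` gives 24%. Compound 1 `COc1cccc2cc(C(=O)NC3CCCC3)c(=N)oc12` gives > 70%, which is a limit of the assay rather than a number. Compound 4 `COc1cccc2cc(C(=O)NC(CO)(CO)CO)c(=N)oc12` differs from compound 3 by 2-hydroxy-1,1-bis(hydroxymethyl)ethyl in place of cyclohexyl on an amide-type nitrogen. Going by the values given here, two measured steps bear on this change: a number 16 percentage points higher from compound 2 to compound 3 (beyond the scatter), and a number at least 46 percentage points lower from compound 1 to compound 2 (beyond the scatter). In both, exchanging a carbon ring for a hydroxyl-bearing chain lowered the read-out, and the reverse exchange raised it. The same direction is expected here, with a drop beyond the scatter, a number 30 percentage points lower from compound 3 to compound 4 (beyond the scatter). Compound 4 is therefore estimated at 10%, with a likely range from 0% to 30%.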

Compound 4, a percentage reported as inhibition, at one concentration (the size of the read-out at that concentration, not a potency): 19%
For compound 4 the middle estimate is 9 percentage points below the measured one; the range from low to high includes it.
By their numbers in this assay, from the lowest: compounds 4 and 2 (each within the scatter of the next); then compound 3. At a limit, above all of these: compound 1.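

Placing 2-hydroxy-1,1-bis(hydroxymethyl)ethyl on the amide-type nitrogen instead of a carbon ring gives a number 21 percentage points lower from compound 3 to compound 4 (beyond the scatter) and a number at least 51 percentage points lower from compound 1 to compound 4 (beyond the scatter). The two hydroxyl-bearing chains cannot be told apart, with 2-hydroxy-1,1-bis(hydroxymethyl)ethyl in place of 1-(hydroxymethyl)propyl giving a number 5 percentage points lower from compound 2 to compound 4 (within the scatter). The step from compound 1 is only a bound, as its value is a limit and not a number: the limit of > 70% in this assay, at which 1 of the 4 values shown sits.

A plain butyl chain, with no hydroxyl, would help separate losing the ring from adding hydroxyl groups. Going by these compounds, whether a chain ending in an amine or a carboxylic acid would match these chains or the carbon rings remains open.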